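Same benzyl swap carried onto a second core

The compounds below may be only part of what the source reports. "The series", "measured", "known", "first", "only" and "open" are said of these compounds alone.

Measured so far:
- compound 1, `N#Cc1c(Nc2ccccc2Cl)nc(SCc2cn(Cc3ccccc3Cl)nn2)nc1-c1ccccc1`: in a functional assay on MCF7 cells (Homo sapiens) for inhibition, read by MTT assay, with a stated time of 72 h (a higher number here means a weaker inhibitor, a lower number a stronger inhibitor), compound 1 gives 1950 nM.
- compound 3, `Cc1ccc(Cn2cc(CSc3nc(Nc4ccccc4Cl)c(C#N)c(-c4ccccc4)n3)nn2)cc1`: in this assay compound 3 gives 34400 nM.
- compound 2, `Cc1ccc(Cn2cc(CSc3nc(Nc4ccc(C)cc4)c(C#N)c(-c4ccccc4)n3)nn2)cc1`: in this assay compound 2 returns only a limit of the assay, > 64000 nM.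

Compound 3 and compound 1 share a core and differ only by 2-chlorophenyl in place of 4-methylphenyl on a saturated chain carbon bound to an aromatic nitrogen. Among the measured compounds shown here, that single change gives an 18-fold lower number from compound 3 to compound 1 (1.25 log units; beyond the scatter), the one clearly resolved step in the set.

The cores of compound 3 and compound 2 differ by 4-methylphenyl in place of 2-chlorophenyl on a nitrogen on an aromatic ring. Between them the number moves by an at least 1.8-fold lower number from compound 2 to compound 3 (0.26 log units; that floor lies within the scatter); the size of that step is open at one end because compound 2 sits at the limit of > 64000 nM in this assay, at which 1 of the 3 values shown sits.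

Compound 4, `Cc1ccc(Nc2nc(SCc3cn(Cc4ccccc4Cl)nn3)nc(-c3ccccc3)c2C#N)cc1`, is not yet measured. It differs from compound 2 by 2-chlorophenyl in place of 4-methylphenyl on a saturated chain carbon bound to an aromatic nitrogen, which is the same change, at the same place, as the one that carries compound 3 to compound 1; the change occurs twice among the compounds shown.

For compound 4 the step in this assay is expected to resemble the earlier one, that is an at least 10-fold lower number from compound 2 to compound 4 (1.02 log units; beyond the scatter) beside an 18-fold lower number from compound 3 to compound 1 (1.25 log units; beyond the scatter). This expectation rests on compound 3 and compound 1 alone, and its starting point is uncertain since compound 2 is known only as a limit, so compound 4 is estimated at 6000 nM, with a range from 1500 nM to 40000 nM.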

Compound 4, half-maximal inhibitory concentration: 9420 nM
Compound 4: the middle estimate sits 1.6-fold (0.20 log units) below what was measured, and the stated range covers the measured number.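

In this assay the change from 4-methylbenzyl to 2-chlorobenzyl gives an at least 6.7-fold lower number from compound 2 to compound 4 (0.83 log units; beyond the scatter), so it lowers the number on both cores shown: the same change on two cores in this assay, an 18-fold lower number (1.25 log units; beyond the scatter) from compound 3 to compound 1 and an at least 6.7-fold lower number (0.83 log units; beyond the scatter) from compound 2 to compound 4; the limit leaves it open whether they differ. The change on the other site, 4-methylphenyl in place of 2-chlorophenyl on a nitrogen on an aromatic ring, gives a 4.8-fold higher number from compound 1 to compound 4 (0.68 log units; beyond the scatter), and this step points the same way as the one read on the core that carries 4-methylbenzyl, though the two cannot be sized against each other: the same change on two cores in this assay, an at least 1.8-fold lower number (0.26 log units; that floor lies within the scatter) from compound 2 to compound 3 and a 4.8-fold lower number (0.68 log units; beyond the scatter) from compound 4 to compound 1; the limit leaves it open whether they differ. Compound 2 gives only a limit of the assay, > 64000 nM, so the direction carries from one core to the other, but whether the change is worth the same on both stays unshown, and two cores do not make a rule for the whole series.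

The compounds shown leave open whether the lower number follows from the chlorine, from its place on the ring, or from the loss of the methyl, since the two substituted rings are only ever exchanged for each other. Also open, from the compounds shown here alone, is whether the step holds when a longer chain replaces the benzyl group, or when an amine or a carboxylic acid sits on that ring.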